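Piperazine nitrogen substituent and cytotoxicity in the shared core

The source may hold more compounds than are shown below. What is called first, only, known or untested is meant among the compounds shown, and "the series" means these compounds.

Compound 1 `CCN(CC)c1ccc2cc(C(=O)c3ccc(N4CCN(C(=O)COc5ccc(Cl)cc5Cl)CC4)cc3)oc2c1` gives 30 nM in a functional assay on HeLa cells (Homo sapiens) for cytotoxicity, read by MTT assay, with a stated time of 48 h; a lower number here means a stronger inhibitor, a higher number a weaker inhibitor.
Compound 2 `CCN(CC)c1ccc2cc(C(=O)c3ccc(N4CCN(S(=O)(=O)c5ccc([N+](=O)[O-])cc5)CC4)cc3)oc2c1` gives > 40000 nM in this assay, which is a limit of the assay and not a number.

Among the measured compounds shown here, compound 1 holds the only numeric value of the pair; the other value is a limit. For the measured compounds named here, the single measured step runs an at least 1300-fold higher number from compound 1 to compound 2 (3.12 log units; beyond the scatter), and this step rests on (the limit of > 40000 nM in this assay, at which 1 of the 2 values shown sits), so its true size is not known beyond that bound.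

Compound 3 `CCN(CC)c1ccc2cc(C(=O)c3ccc(N4CCN(S(=O)(=O)c5ccc(F)cc5)CC4)cc3)oc2c1` differs from compound 1 in one place: (4-fluorophenyl)sulfonyl in place of ((2,4-dichlorophenoxy)methyl)carbonyl on an amine nitrogen in a ring. This change shares with the measured step the swap of the carbonyl-linked group on the ring nitrogen for a sulfonyl-linked aryl group; it differs from compound 2 only in carrying fluorine rather than nitro on that aryl ring. Given the size of an at least 1300-fold higher number from compound 1 to compound 2 (3.12 log units; beyond the scatter), a large rise in this assay is expected for compound 3, with the aryl substituent as the open question. The expected step is a 500-fold higher number from compound 1 to compound 3 (2.70 log units; beyond the scatter). Compound 3 is expected to give about 15000 nM, in a range from 1500 nM to 40000 nM, with a real chance that only a limit is returned.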

Compound 3, half-maximal inhibitory concentration: 21600 nM
The estimate for compound 3 lay 1.4-fold (0.16 log units) below the measured number, and the stated range covers the measured number.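

Among the compounds shown here, with compound 3 the swap on the ring nitrogen gains a measured size for the first time: in this assay the change is a 720-fold higher number from compound 1 to compound 3 (2.86 log units; beyond the scatter), so the large rise no longer rests on a bound alone and holds with fluoro as well as with nitro on the aryl ring of the sulfonyl group. The step of fluoro in place of nitro on an aromatic carbon reads an at least 1.8-fold lower number from compound 2 to compound 3 (0.26 log units; that floor lies within the scatter), so the shown values do not resolve any effect of this aryl substituent. The value of compound 2 is a limit and not a number: the limit of > 40000 nM in this assay, at which 1 of the 3 values shown sits.

Going by these compounds, the carbonyl-to-sulfonyl link and the loss of the 2,4-dichlorophenoxy part change together in both steps from compound 1, so the share of each in the rise stays open. On these data alone, a (2,4-dichlorophenyl)sulfonyl group or a (4-fluorophenoxy)acetyl group on the ring nitrogen would separate the two, and the effect of an amine or a carboxylic acid on the aryl ring is also open.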